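The source may report more compounds than this note shows. Statements on the series, on what has been measured and on what is new or still open speak of the compounds shown alone.

The measured compounds and their values in a functional assay for activation of Alpha-1B adrenergic receptor (Homo sapiens), read by calcium flux; on this read-out lower numbers stand for an effect already at smaller amounts and higher numbers for an effect only at larger amounts of compound:

compound 1, `Cc1cc(-c2ccccc2NCC2=NCCN2)on1`: 95.5 nM
compound 2, `Cc1noc(-c2ccccc2NCC2=NCCN2)n1`: a limit of the assay, < 5020 nM
compound 3, `CO/N=C(\C)c1ccccc1NCC1=NCCN1`: a limit of the assay, < 5020 nM

For the measured compounds named here, compound 1 stands as the only compound with an actual number in this assay; the other two values are limits, as the limit of < 5020 nM in this assay, at which 2 of the 3 values shown sit, records. Going by these compounds, the step that the limit leaves unreadable from compound 1 to compound 2 cannot be sized, and the same holds for a step that the limit leaves unreadable from compound 1 to compound 3; whether either change helps or hurts beyond the usual scatter stays open.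

Compound 4, `CC/C(=N\OC)c1ccccc1NCC1=NCCN1`, has not yet been measured. It differs from compound 1 in one place: a group of 6 heavy atoms (4 carbon, 1 nitrogen, 1 oxygen; no ring) in place of a group of 6 heavy atoms (4 carbon, 1 nitrogen, 1 oxygen; one five-membered aromatic ring with 2 hetero atoms), on an aromatic carbon. Going by the values given here, of the measured steps, the one from compound 1 to compound 3 is the closest relative, as compound 3 also carries a group with no ring on that aromatic carbon, but its size is unreadable, so it gives no direction. With no readable step to lean on, the estimate for compound 4 stays broad and is centred only a little away from compound 1. Compound 4 is expected to give 300 nM in this assay, with a range from 50 nM to 3000 nM. This estimate amounts to an expected step of a 3.1-fold higher number from compound 1 to compound 4 (0.50 log units; beyond the scatter).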

Compound 4, half-maximal effective concentration: < 100000 nM
Compound 4 ended at the assay's limit (the forecaster's own chance of this, stated with the estimate: 30%); the middle value does not contradict the limit.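

In this assay compound 4 gives < 100000 nM as a limit of the assay, not a number, and none of its steps from compound 1, compound 2 or compound 3 can be read. The compounds shown leave open how far any replacement of the 3-methyl-1,2-oxazol-5-yl group of compound 1 moves the value, and whether methyl in place of hydrogen separates compound 3 from compound 4.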